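A few compounds are considered here, and "the series" means these few. Any claim that something is new, unique, unknown or untested is made for them only; others in the source may bear on it.

Compound 3 `Cc1cc(-c2ccsc2)cn2c(CSCCc3ccccc3)cnc12` carries a thiophen-3-yl group on the shared core. In an ADME assay on HEL cells (Homo sapiens) for cytotoxicity, with a stated time of 3 days (on this read-out higher numbers stand for lower toxicity in this test and lower numbers for higher toxicity in this test), compound 3 gives >= 4 ug/mL, which is a limit of the assay and not a number. Compound 2 `Cc1cc(-c2ccc(O)cc2)cn2c(CSCCc3ccccc3)cnc12` gives >= 100 ug/mL in this assay, again a limit. The step that the two limits leave unreadable from compound 2 to compound 3 therefore cannot be read, because both ends sit at the limits described by the limit of >= 100 ug/mL in this assay, at which 1 of the 3 values shown sits, and (the limit of >= 4 ug/mL in this assay, at which 1 of the 3 values shown sits). Within the data shown here, compound 1 `Cc1cc(-c2cccc(F)c2)c2ncc(CSCCc3ccccc3)n2c1`, the one measured compound with a number, gives 20 ug/mL in this assay.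

Compound 4 `Cc1cc(-c2cccc([N+](=O)[O-])c2)cn2c(CSCCc3ccccc3)cnc12` is the unmeasured compound; it differs from compound 3 by 3-nitrophenyl in place of thiophen-3-yl on an aromatic carbon. Among the measured compounds shown here, no measured step shares this change, so the size of the expected step that the limit leaves unreadable from compound 3 to compound 4 rests on the spread of the three values shown, and compound 4 is estimated to land near the number of compound 1 rather than at either limit. For compound 4 the estimate in this assay is 20 ug/mL, with a range from 4 ug/mL to 100 ug/mL.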

Compound 4, minimum cytotoxic concentration: >= 100 ug/mL
Compound 4: only a limit was reported; the forecaster's own chance of this, stated with the estimate: 40%; middle value at least 5.0-fold (0.69 log units) away from the limit.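

No step can be read between compound 4 and either compound 2 or compound 3, as all three values are limits of the assay and not numbers in this assay. The compounds shown leave open how the 4-hydroxyphenyl, thiophen-3-yl and 3-nitrophenyl groups rank against one another in this assay.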